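Amine head variation on the aminoalkoxy side chain

A few compounds are considered here, and "the series" means these few. Any claim that something is new, unique, unknown or untested is made for them only; others in the source may bear on it.

Measured so far:
compound 1, `CN(C)CCCOc1c(OCc2ccccc2)cc(O)c2c(=O)cc(-c3ccccc3)oc12`: 4950 nM
compound 2, `O=c1cc(-c2ccccc2)oc2c(OCCCN3CCCC3)c(OCc3ccccc3)cc(O)c12`: 2660 nM
compound 3, `CCN(CC)CCCCOc1c(OCc2ccccc2)cc(O)c2c(=O)cc(-c3ccccc3)oc12`: 1650 nM

All three were run in a functional assay on HepG2 cells (Homo sapiens) for cytotoxicity, read by MTT assay, with a stated time of 72 h; on this read-out higher numbers stand for weaker inhibition and lower numbers for stronger inhibition. Compound 3 holds the lowest of the three numbers; its nearest neighbour is compound 2 and its furthest is compound 1. Among the compounds with values here, only the step of a 3.0-fold lower number from compound 1 to compound 3 (0.48 log units; beyond the scatter) goes beyond the scatter, and it is modest; the steps of a 1.9-fold lower number from compound 1 to compound 2 (0.27 log units; within the scatter) and a 1.6-fold lower number from compound 2 to compound 3 (0.21 log units; within the scatter) both stay within it.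

Compound 4, `CN1CCN(CCCCOc2c(OCc3ccccc3)cc(O)c3c(=O)cc(-c4ccccc4)oc23)CC1`, has not yet been run in this assay. It differs from compound 3 by 4-methylpiperazin-1-yl in place of diethylamino on a saturated chain carbon, four bonds along the chain from an oxygen on an aromatic ring. Within the data shown here, no measured pair swaps a chain amine for a 4-methylpiperazin-1-yl group, so no step bears on this change directly. The nearest in kind is the swap of a chain amine for a ring amine, the step of a 1.9-fold lower number from compound 1 to compound 2 (0.27 log units; within the scatter), which stayed within the scatter, and every amine exchange seen so far has moved the number no further than the modest step of a 3.0-fold lower number from compound 1 to compound 3 (0.48 log units; beyond the scatter). The expected step of a 1.5-fold higher number from compound 3 to compound 4 (0.18 log units; within the scatter) is therefore none beyond the scatter, with a slight lean toward a higher number. Compound 4 is estimated at 2500 nM, with a range from 1000 nM to 6500 nM.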

Compound 4, half-maximal inhibitory concentration: 1500 nM
The estimate for compound 4 lay 1.7-fold (0.22 log units) above the measured number; the measured number falls inside the stated range.
By their numbers in this assay, from the lowest: compounds 4, 3, 2 and 1 (each within the scatter of the next, the first and the last beyond it).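

In this assay, the step of a 1.1-fold lower number from compound 3 to compound 4 (0.04 log units; within the scatter) is the only exchange of amine head shown at four bonds along the chain from an oxygen on an aromatic ring, so an open diethylamino group and 4-methylpiperazin-1-yl, with its six-membered non-aromatic ring and 2 hetero atoms, can be compared there directly. Compound 2 also stays within reach of the new head, with a 1.8-fold lower number from compound 2 to compound 4 (0.25 log units; within the scatter) as the step, whereas a 3.3-fold lower number from compound 1 to compound 4 (0.52 log units; beyond the scatter) is the second modest step beyond the scatter, alongside a 3.0-fold lower number from compound 1 to compound 3 (0.48 log units; beyond the scatter) for the diethylamino compound; among the four compounds, only compound 1 is separated from any other, and only from compound 3 and compound 4. No measurement is available that gives a reason for these numbers.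

The steps from compound 1 and compound 2 combine the change of head with a change of chain, so a dimethylamino or pyrrolidin-1-yl head on the chain of compound 3 would be needed to separate the two. On these data alone, whether morpholin-4-yl, piperidin-1-yl or a primary amine on that chain would also stay within the scatter of compound 3 remains open, as does the effect of a longer chain.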